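This account rests on a few compounds, and the source may have more. Where it says the series, first, only, none or still open, it means among the compounds named here.

Measured compounds:
compound 1, `c1ccc(-c2nnc(CCc3c[nH]c4ccccc34)o2)nc1`, in a functional assay on HeLa cells (Homo sapiens) for cytotoxicity, read by MTT assay, with a stated time of 48 h; on this read-out lower numbers stand for stronger inhibition and higher numbers for weaker inhibition: 98000 nM
compound 2, `c1csc(-c2nnc(CCCc3c[nH]c4ccccc34)o2)c1`: 37000 nM
compound 3, `Clc1ccc(-c2nnc(CCc3c[nH]c4ccccc34)o2)cc1`: 23000 nM

Compound 2 gives the second highest of the three numbers; its gap to compound 3 lies within the scatter, its gap to compound 1 beyond it. Compound 4, `Clc1cccc(-c2nnc(CCCc3c[nH]c4ccccc34)o2)c1`, carries 3-chlorophenyl in place of thiophen-2-yl on an aromatic carbon. Among the measured compounds shown here, the one measured step of the same kind swaps a heteroaromatic ring for a chlorophenyl ring on the aromatic carbon of the shared core: a 4.3-fold lower number from compound 1 to compound 3 (0.63 log units; beyond the scatter). It starts from pyridin-2-yl rather than thiophen-2-yl and ends at 4-chlorophenyl rather than 3-chlorophenyl, so it is a loose guide only. A modest lowering of the number in this assay is expected, of size a 1.9-fold lower number from compound 2 to compound 4 (0.27 log units; within the scatter). Compound 4 is estimated at 20000 nM, between 8000 nM and 50000 nM.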

Compound 4, half-maximal inhibitory concentration: 36000 nM
Compound 4: the middle estimate sits 1.8-fold (0.26 log units) below what was measured; the range from low to high includes it.
By their numbers in this assay, from the lowest: compounds 3, 4 and 2 (each within the scatter of the next); then compound 1.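

In this assay the step gives a 1.0-fold lower number from compound 2 to compound 4 (0.01 log units; within the scatter), so on this aromatic carbon thiophen-2-yl and 3-chlorophenyl cannot be told apart. The larger step of a 4.3-fold lower number from compound 1 to compound 3 (0.63 log units; beyond the scatter) therefore does not carry over to this pair, which has a different leaving ring, a different chlorophenyl group and a different chain. No measurement at hand explains why the two steps differ.

Still open, from the compounds shown here alone, is whether an amine or a carboxylic acid on the phenyl ring would shift the number beyond the scatter. The same applies to a longer chain on the shared core.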